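The source may report more compounds than this note shows. Statements on the series, on what has been measured and on what is new or still open speak of the compounds shown alone.

Measured so far in a functional assay on NCI-H460 cells (Homo sapiens) for antiproliferative activity; on this read-out lower numbers stand for stronger inhibition and higher numbers for weaker inhibition
- compound 1 `COc1ccc(N=C2NC(=O)/C(=C\c3ccc(N(C)C)cc3)S2)cc1` gives 2520 nM
- compound 2 `CC(=O)Nc1ccc(/C=C2/S/C(=N/c3cccc(Cl)c3)NC2=O)cc1` gives 1190 nM
- compound 3 `CN(C)c1ccc(/C=C2/SC(=Nc3ccc(O)cc3)NC2=O)cc1` gives 1320 nM

On these numbers, compound 3 stands within the scatter of both compound 1 and compound 2. The next step leads to compound 4 `CN(C)c1ccc(/C=C2/SC(=Nc3ccccc3)NC2=O)cc1` by hydrogen in place of hydroxy on an aromatic carbon. Going by the values given here, one measured step bears on this oxygen: a 1.9-fold lower number from compound 1 to compound 3 (0.28 log units; within the scatter) is hydrogen in place of methyl on it. Among the compounds with values here, no measured step removes that oxygen, so the evidence is thin. Within the data shown here, with a 1.9-fold lower number from compound 1 to compound 3 (0.28 log units; within the scatter) as the only guide, no step beyond the scatter is expected in this assay and no direction is favoured. The estimate means a 1.4-fold higher number from compound 3 to compound 4 (0.13 log units; within the scatter) as the expected step. Compound 4 is estimated at 1800 nM with 700 nM to 4500 nM as the expected range.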

Compound 4, half-maximal inhibitory concentration: 500 nM
Compound 4: the middle estimate sits 3.6-fold (0.56 log units) above what was measured, outside the stated range (below it).
By their numbers in this assay, from the lowest: compound 4; then compounds 2, 3 and 1 (each within the scatter of the next, the first and the last beyond it).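

In this assay the change from 4-hydroxyphenyl to phenyl gives a step beyond the scatter (a 2.6-fold lower number from compound 3 to compound 4 (0.42 log units; beyond the scatter)), and removing methoxy from the same place does too (a 5.0-fold lower number from compound 1 to compound 4 (0.70 log units; beyond the scatter)). Hydroxy and methoxy alone had not separated (a 1.9-fold lower number from compound 1 to compound 3 (0.28 log units; within the scatter)), so in these three compounds the difference appears only when the oxygen leaves the ring. Nothing measured here explains the step. As far as these compounds go, whether a fluorine, an amine or a carboxylic acid at this place would read like compound 4 or like compound 3 remains open.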